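This account rests on a few compounds, and the source may have more. Where it says the series, first, only, none or still open, it means among the compounds named here.

Measured so far in an in vitro assay on HEK-tsA201 cells for antagonist activity at Neuronal acetylcholine receptor; alpha4/beta2 (Homo sapiens), read by fluorescence and calcium flux; a lower number here means a stronger inhibitor, a higher number a weaker inhibitor:
- compound 1 `CCCOc1ccc(C(=O)Nc2cccc(CC)n2)cc1`: 37600 nM
- compound 2 `CCCNc1cccc(NC(=O)c2ccc(OCCC)cc2)n1`: 15400 nM
- compound 3 `CCCCCCNc1cccc(NC(=O)c2ccc(OCCC)cc2)n1`: > 100000 nM, a limit of the assay and not a number

Compound 3 therefore stands only at the assay limit (the limit of > 100000 nM in this assay, at which 1 of the 3 values shown sits), the weakest position among the three values shown. The steps that reach it run an at least 2.6-fold higher number from compound 1 to compound 3 (0.42 log units; beyond the scatter) and an at least 6.4-fold higher number from compound 2 to compound 3 (0.81 log units; beyond the scatter), so lengthening the chain on the ring nitrogen from propylamino to hexylamino pushed the number past the limit, while the shorter chain gave a 2.4-fold lower number from compound 1 to compound 2 (0.39 log units; beyond the scatter).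

The next compound, compound 4 `CCCOc1ccc(C(=O)Nc2cccc(Nc3ccccc3)n2)cc1`, changes compound 3 by phenyl in place of hexyl on a nitrogen on an aromatic ring. Among the compounds with values here, no measured step swaps a chain for an aromatic ring at this position, so the bearing evidence is indirect: the hexyl chain is the one clearly disfavoured group, and the smaller propylamino of compound 2 sits well inside the measurable range. Going by these compounds, removing the hexyl chain is therefore expected to lower the number in this assay, though how far an anilino reaches is unknown; the step from compound 3 to compound 4 is estimated as an at least 2.5-fold lower number from compound 3 to compound 4 (0.39 log units; beyond the scatter).

Compound 4 is estimated at 40000 nM, with a range from 10000 nM to 200000 nM.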

Compound 4, half-maximal inhibitory concentration: > 100000 nM
Compound 4 was reported as a limit; the forecaster's own chance of this, stated with the estimate: 35%; at least 2.5-fold (0.39 log units) between middle value and limit.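

In this assay compound 4 gives > 100000 nM, which is a limit of the assay and not a number. Phenyl in place of propyl on a nitrogen on an aromatic ring gives an at least 6.4-fold higher number from compound 2 to compound 4 (0.81 log units; beyond the scatter), and anilino in place of ethyl on an aromatic carbon gives an at least 2.6-fold higher number from compound 1 to compound 4 (0.42 log units; beyond the scatter), so among the groups shown, propylamino remains the only amino group with a measured number. The loss at this position is therefore not confined to a long saturated chain: a six-membered aromatic ring of carbon only, with the same count of heavy atoms as hexyl, also ends at the limit, and the step from compound 3 to compound 4 cannot be read, so hexylamino and anilino cannot be ranked against each other: the limit of > 100000 nM in this assay, at which 2 of the 4 values shown sit.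

Going by these compounds, it remains open where between propylamino and hexylamino the number leaves the measurable range, which a butylamino or pentylamino group would help to place. Also open, on these data alone, is whether a benzylamino group, or a methylamino or unsubstituted amine smaller than propylamino, would give a lower number in this assay than the limit reached with anilino.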